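Lengthening the ester chain of compound 3

The compounds below may be only part of what the source reports. "The series", "measured", "known", "first", "only" and "open" are said of these compounds alone.

Measured in an ADME assay on Vero cells (Chlorocebus sabaeus) for cytotoxicity, read by reporter gene assay, with a stated time of 4 days; a lower number here means a stronger inhibitor, a higher number a weaker inhibitor:
- compound 1 `CCCCCC(=O)NCC(C)(C)CC1=C(O)C(=O)c2ccccc2C1=O`: 46600 nM
- compound 2 `CCCCCCCCC(=O)NCC(C)(C)CC1=C(O)C(=O)c2ccccc2C1=O`: 16700 nM
- compound 3 `CCCCCCC(=O)OCC(C)(C)CC1=C(O)C(=O)c2ccccc2C1=O`: 99300 nM

Compound 3 stands highest of the three numbers. The nearest is compound 1, and the furthest is compound 2.

Compound 4 `CCCCCCCCCCCCCCCCCC(=O)OCC(C)(C)CC1=C(O)C(=O)c2ccccc2C1=O` has not yet been measured. Its difference from compound 3 is undecyl in place of hydrogen on a saturated chain carbon, six bonds along the chain from a carbonyl carbon.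

Within the data shown here, the closest precedent is a 2.8-fold lower number from compound 1 to compound 2 (0.45 log units; beyond the scatter), a modest change with propyl in place of hydrogen, but it was seen with the amide and not with the ester. The other measured step, a 2.1-fold higher number from compound 1 to compound 3 (0.33 log units; beyond the scatter), is also modest. It shows only that the ester and amide differ, and it says nothing about chain length. Among the measured compounds shown here, no pair of esters differing in chain length has been measured, and undecyl is a much larger addition than propyl, so the extrapolation is loose.

A lower number in this assay is expected, of about the size seen with propyl. The expected outcome is a 3.3-fold lower number from compound 3 to compound 4 (0.52 log units; beyond the scatter). For compound 4 the estimated value is 30000 nM, with an expected range of 8000 nM to 120000 nM.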

Compound 4, half-maximal inhibitory concentration: 15500 nM
Compound 4: middle estimate off by 1.9-fold (0.29 log units), on the high side, and the stated range covers the measured number.
By their numbers in this assay, from the lowest: compounds 4 and 2 (each within the scatter of the next); then compound 1; then compound 3.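

In this assay, the ester series now has its first pair differing in chain length: undecyl in place of hydrogen on a saturated chain carbon, six bonds along the chain from a carbonyl carbon, gives a 6.4-fold lower number from compound 3 to compound 4 (0.81 log units; beyond the scatter), so this position tolerates a large unbranched addition without the number rising. Among these compounds, a lower number on chain extension is therefore no longer confined to the amides, where the only earlier example was a 2.8-fold lower number from compound 1 to compound 2 (0.45 log units; beyond the scatter), although the two steps add different groups at different places, so their sizes give no rate of change with chain length. Nothing measured here explains the change at this position.

From the compounds shown here alone, two questions remain open in the ester series. Whether esters with chains of intermediate length fall in order between compound 3 and compound 4, or whether the number turns at some length, cannot be told from this single pair. Also open, going by these compounds, is how a terminal amine or a carboxylic acid at the end of the chain, or an equally long chain on the amide of compound 1, would read in this assay.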